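The compounds below may be only part of what the source reports. "The series", "measured", "known", "first", "only" and "open" are said of these compounds alone.

Measured in a physicochemical assay for solubility, in phosphate buffer; on this read-out lower numbers stand for lower solubility and higher numbers for higher solubility:
- Compound 1 `Cc1cc(N[C@H](CCCCN)C(=O)NO)cc(C)c1F`: > 5 ug/mL
- Compound 2 `Cc1cc(CNCCCC[C@@H](Nc2cc(C)c(F)c(C)c2)C(=O)NO)ccc1F`: > 5 ug/mL
- Compound 3 `Cc1cc(NC(=O)NCCCC[C@@H](Nc2cc(C)c(F)c(C)c2)C(=O)NO)ccc1F`: > 5 ug/mL

Each entry is a limit and not a number, as the limit of > 5 ug/mL in this assay, at which 3 of the 3 values shown sit, shows. The position of compound 2 is therefore known only as a limit, > 5 ug/mL.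

Compound 4 `Cc1cc(N[C@H](CCCCNCc2ccccc2F)C(=O)NO)cc(C)c1F` is unmeasured in this assay. Its change is 2-fluorophenyl in place of 4-fluoro-3-methylphenyl on a saturated chain carbon bound to an amine nitrogen.

For the measured compounds named here, the only measured step bearing on this change is a step that the two limits leave unreadable from compound 1 to compound 2, which gives no readable size. No direction can be drawn from it, so no shift beyond the scatter is expected. The expected change is a step that the limit leaves unreadable from compound 2 to compound 4. Compound 4 is estimated at 10 ug/mL, with an expected range of 5 ug/mL to 40 ug/mL.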

Compound 4, solubility: > 5 ug/mL
Compound 4: a limit, no number; the forecaster's own chance of this, stated with the estimate: 70%; the middle value does not contradict the limit.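

No new step can be read for compound 4 against compound 1 or compound 2, as each result is a limit and not a number: the limit of > 5 ug/mL in this assay, at which 4 of the 4 values shown sit.

The compounds shown leave open whether 2-fluorobenzyl and 4-fluoro-3-methylbenzyl differ in solubility at all.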